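The source may hold more compounds than are shown below. What is called first, only, known or untested is meant among the compounds shown, and "the series" means these compounds.

Among the measured compounds shown here, compound 2 `Cc1cc(O)c(C2=NN(c3ccc(S(N)(=O)=O)cc3)C(/C=C/c3ccccc3)C2)cc1Cl` is one of two compounds measured in a functional assay on HOP-62 cells (Homo sapiens) for antiproliferative activity, with a stated time of 48 h; on this read-out lower numbers stand for stronger inhibition of growth and higher numbers for weaker inhibition of growth. Compound 1 `Cc1cc(O)c(C2=NN(c3ccc(S(N)(=O)=O)cc3)C(c3ccccc3Cl)C2)cc1Cl` gives 4160 nM in this assay, while compound 2 gives 14100 nM, the higher of the two numbers. For the measured compounds named here, the single step seen so far, a 3.4-fold higher number from compound 1 to compound 2 (0.53 log units; beyond the scatter), therefore moved toward weaker inhibition of growth. Compound 3 `COc1ccc(C2CC(c3cc(Cl)c(C)cc3O)=NN2c2ccc(S(N)(=O)=O)cc2)c(OC)c1OC` has not yet been measured in this assay. It differs from compound 2 by 2,3,4-trimethoxyphenyl in place of 2-phenylethenyl on a saturated ring carbon. Going by the values given here, the only measured step that touches the same saturated ring carbon is a 3.4-fold higher number from compound 1 to compound 2 (0.53 log units; beyond the scatter), in which the 2-chlorophenyl group gave way to the 2-phenylethenyl group and the number rose. Among the compounds with values here, the change to compound 3 brings a six-membered aromatic ring of carbon only back onto that carbon, though carrying three methoxy groups rather than a chlorine, so no measured pair matches it directly. The step is therefore expected to run back toward lower numbers, about a 2.4-fold lower number from compound 2 to compound 3 (0.37 log units; beyond the scatter), without a size that can be foretold closely. For compound 3 the estimate in this assay is 6000 nM, with a range from 2000 nM to 20000 nM.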

Compound 3, concentration for total growth inhibition: 4560 nM
The estimate for compound 3 lay 1.3-fold (0.12 log units) above the measured number; measured number inside the range.
By their numbers in this assay, from the lowest: compounds 1 and 3 (each within the scatter of the next); then compound 2.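

In this assay, among the compounds shown here, the step from the 2-phenylethenyl group to the 2,3,4-trimethoxyphenyl group on the saturated ring carbon gives a 3.1-fold lower number from compound 2 to compound 3 (0.49 log units; beyond the scatter), the first measured change at this position toward stronger inhibition of growth. The comparison with the 2-chlorophenyl group gives a 1.1-fold higher number from compound 1 to compound 3 (0.04 log units; within the scatter), so these two substituted phenyl groups cannot be told apart in this assay despite their different substituents, and among the three compounds only the 2-phenylethenyl group stands apart, beyond the scatter from both. Nothing given here explains why the numbers fall this way.

The three compounds leave open whether a six-membered aromatic ring of carbon only is what matters on this carbon, or whether a pyridine ring, a cyclohexyl ring or a saturated 2-phenylethyl chain would give numbers like those of compound 1 and compound 3. They also leave open how a single methoxy group, or an unsubstituted phenyl ring, would compare with the 2,3,4-trimethoxyphenyl and 2-chlorophenyl groups.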